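Working notes: from compound 2 to compound 4

The source may report more compounds than this note shows. Statements on the series, on what has been measured and on what is new or still open speak of the compounds shown alone.

compound 1 `COc1cc(OC)c(C(=O)/C=C/c2ccccc2OC)c(OC)c1`: 4500 nM
compound 2 `COc1cccc(/C=C/C(=O)c2c(OC)cc(OC)cc2OC)c1`: 3900 nM
compound 3 `COc1cc(O)c(C(=O)/C=C/c2ccccc2OC)c(OC)c1`: 10000 nM

In a functional assay on Caco-2 cells (Homo sapiens) for cytotoxicity, with a stated time of 48 h (on this read-out higher numbers stand for weaker inhibition and lower numbers for stronger inhibition), compound 2 gives 3900 nM, within the scatter of compound 1, while compound 3 stands higher at 10000 nM.

Compound 4 `COc1cc(OC)c(C(=O)/C=C/c2ccc(Cl)cc2)c(OC)c1` has not been measured. It carries 4-chlorophenyl in place of 3-methoxyphenyl on a double-bonded chain carbon bound to a double-bonded chain carbon.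

Among the compounds with values here, only one measured step falls at this place: 3-methoxyphenyl in place of 2-methoxyphenyl gave a 1.2-fold lower number from compound 1 to compound 2 (0.06 log units; within the scatter). The other, a 2.2-fold higher number from compound 1 to compound 3 (0.35 log units; beyond the scatter), is modest and concerns hydrogen in place of methyl on an oxygen on an aromatic ring, so it bears on this change only as a guide to size. Within the data shown here, no measured compound carries 4-chlorophenyl, so the evidence is thin.

No step beyond the scatter is expected in this assay, and no direction is favoured. The expected step is a 1.1-fold higher number from compound 2 to compound 4 (0.03 log units; within the scatter). For compound 4 the estimate is 4200 nM, with an expected range from 1500 nM to 11000 nM.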

Compound 4, half-maximal inhibitory concentration: 5700 nM
The estimate for compound 4 lay 1.4-fold (0.13 log units) below the measured number, and the stated range covers the measured number.
By their numbers in this assay, from the lowest: compounds 2, 1, 4 and 3 (each within the scatter of the next, the first and the last beyond it).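

In this assay, the place on a double-bonded chain carbon bound to a double-bonded chain carbon now also accepts a group with chlorine and no oxygen: 4-chlorophenyl in place of 3-methoxyphenyl gives a 1.5-fold higher number from compound 2 to compound 4 (0.16 log units; within the scatter) and 4-chlorophenyl in place of 2-methoxyphenyl gives a 1.3-fold higher number from compound 1 to compound 4 (0.10 log units; within the scatter) on the same core. Compound 1, compound 2 and compound 4 thus stay within the scatter of one another across three different groups at this place, so neither methoxy group is needed to hold the number in this range. No measured evidence accounts for this result.

Still open, on these data alone, is whether an amine, a carboxylic acid or a longer chain at this place would give a step beyond the scatter. Also open, as far as these compounds go, is whether 4-chlorophenyl behaves the same way on the core of compound 3, which has hydrogen in place of methyl on an oxygen on an aromatic ring.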